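This account rests on a few compounds, and the source may have more. Where it says the series, first, only, none or still open, it means among the compounds named here.

In a functional assay on MCF7 cells (Homo sapiens) for inhibition, read by CCK-8 assay, with a stated time of 48 h (on this read-out higher numbers stand for weaker inhibition and lower numbers for stronger inhibition), compound 2 (`COc1cc(-c2ccnc3cc(-c4ccccc4)nn23)cc(OC)c1OC`) gives 254 nM and stands second highest of three numbers, with compound 1 (`COc1cc(-c2ccnc3cc(-c4ccc(C)c(C)c4)nn23)cc(OC)c1OC`) lower at 26 nM and compound 3 (`COc1cc(-c2ccnc3cc(-c4cccc(C)c4)nn23)cc(OC)c1OC`) higher at 1080 nM in the same read-out. The next change is 1-methyl-1H-pyrazol-4-yl in place of hydrogen on an aromatic carbon, and it leads to compound 4 (`COc1cc(-c2ccnc3cc(-c4ccc(-c5cnn(C)c5)cc4)nn23)cc(OC)c1OC`).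

Among the measured compounds shown here, three measured steps bear on this, all involving only methyl groups on the same outer ring. Removing both methyl groups gives a 9.8-fold higher number from compound 1 to compound 2 (0.99 log units; beyond the scatter) and is modest. Removing only the methyl on the carbon that carries the new group in compound 4 gives a 42-fold higher number from compound 1 to compound 3 (1.62 log units; beyond the scatter) and is large. Adding the remaining single methyl gives a 4.3-fold higher number from compound 2 to compound 3 (0.63 log units; beyond the scatter) and is modest. For the measured compounds named here, a methyl on that carbon therefore goes with the lower number in the one pair that tests it, but no measured compound carries a ring there, so the transfer to a far larger group is uncertain.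

A modest step towards a lower number is expected, and the expected size is a 2.5-fold lower number from compound 2 to compound 4 (0.40 log units; beyond the scatter) in this assay on this estimate. Compound 4 is estimated at 100 nM with an expected range from 12 nM to 800 nM in this read-out.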

Compound 4, half-maximal inhibitory concentration: 274 nM
Compound 4: the middle estimate sits 2.7-fold (0.44 log units) below what was measured, and the stated range covers the measured number.
By their numbers in this assay, from the lowest: compound 1; then compounds 2 and 4 (each within the scatter of the next); then compound 3.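

In this assay, among the compounds shown here, the new result is a 1.1-fold higher number from compound 2 to compound 4 (0.03 log units; within the scatter) and so gives the first reading of a ring on the aromatic carbon para to a large group: with 1-methyl-1H-pyrazol-4-yl there, the number cannot be told apart from that with hydrogen. For the compounds shown here, the earlier compounds carried only methyl groups on this outer ring, and the one pair testing this carbon showed a 42-fold higher number from compound 1 to compound 3 (1.62 log units; beyond the scatter) on loss of its methyl, so a methyl there went with the lower number, a link that does not reappear for the much larger ring in this single pair. Nothing available here accounts for why the two numbers read alike.

From the compounds shown here alone, it remains open whether groups of other kinds on this carbon, such as an amine, a carboxylic acid or a longer chain, would also read alike with hydrogen or would depart from it. Also open, going by these compounds, are whether the methyl on the pyrazole ring contributes anything, and whether 1-methyl-1H-pyrazol-4-yl would read the same on the ring of compound 3, which already carries a methyl.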